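The source may report more compounds than this note shows. Statements on the series, on what has been measured and on what is new or still open speak of the compounds shown alone.

Measured so far:
- compound 1, `Cc1ccccc1C(=O)Nc1nnc(-c2ccc(Cl)cc2)s1`, 158 nM in a functional assay on the whole organism (integument) for inhibition, with Chilo suppressalis as the target, read by scintillation counting, with a stated time of 72 h; a higher number here means a weaker inhibitor, a lower number a stronger inhibitor
- compound 2, `COc1ccccc1C(=O)Nc1nnc(-c2ccc(Cl)cc2)s1`, 53.7 nM in this assay
- compound 3, `COc1cccc(OC)c1C(=O)Nc1nnc(-c2ccc(C(C)C)cc2)s1`, 398 nM in this assay

Compound 3 gives the highest of the three numbers: compound 1 sits nearest, compound 2 furthest, both lower by steps beyond the scatter. Among the compounds with values here, the only single-site step in the set is a 2.9-fold lower number from compound 1 to compound 2 (0.47 log units; beyond the scatter), which concerns the amide-bearing ring and not the ring altered here.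

Compound 4, `COc1cccc(OC)c1C(=O)Nc1nnc(-c2ccc(-c3ccccc3)cc2)s1`, differs from compound 3 by phenyl in place of isopropyl on an aromatic carbon. Within the data shown here, no measured step covers this site, so the expectation rests on compound 3 alone: the number is estimated to stay near its own, with a 1.0-fold higher number from compound 3 to compound 4 (0.00 log units; within the scatter) as the expected step, not beyond the scatter. Compound 4 is therefore estimated at 400 nM, within 150 nM to 1100 nM.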

Compound 4, half-maximal inhibitory concentration: 195 nM
The estimate for compound 4 lay 2.1-fold (0.31 log units) above the measured number, within the range that was stated.
By their numbers in this assay, from the lowest: compound 2; then compounds 1 and 4 (each within the scatter of the next); then compound 3.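

Within the data shown here, at the aromatic carbon that carries isopropyl in compound 3, the first measured change in this assay is phenyl in place of isopropyl, with a 2.0-fold lower number from compound 3 to compound 4 (0.31 log units; beyond the scatter) as its step. Thus, on this core, a six-membered aromatic ring with more heavy atoms than isopropyl is accepted at this site, and the number falls rather than rises. No supporting data bear on why the number moved.

On these data alone, whether an amine, a carboxylic acid or a longer alkyl chain at this carbon would lower or raise the number remains open. Also open, as far as these compounds go, is whether the step carries over when the amide-bearing ring has a single methoxy in place of the two in compound 3.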